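A few compounds are considered here, and "the series" means these few. Any claim that something is new, unique, unknown or untested is made for them only; others in the source may bear on it.

Compound 1 `COc1cc(OC)c(OC)cc1/C=C/C(=O)c1ccc(Cl)cc1`: 58500 nM
Compound 2 `COc1cc(OC)c(OC)cc1/C=C/C(=O)c1ccc(O)cc1`: 155000 nM
Compound 3 `COc1cc(OC)c(OC)cc1/C=C/C(=O)c1ccc(Br)cc1`: not yet measured

In a functional assay on SW982 cells (Homo sapiens) for inhibition, read by MTT assay, with a stated time of 72 h (on this read-out higher numbers stand for weaker inhibition and lower numbers for stronger inhibition), compound 2 has the higher number of the two at 155000 nM, so it is the weaker inhibitor so far. Compound 3 keeps the shared core and changes one group, with bromo in place of hydroxy on an aromatic carbon, turning 4-hydroxyphenyl into 4-bromophenyl: bromo in place of hydroxy on an aromatic carbon.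

Within the data shown here, only one measured step bears on this change. It is a 2.6-fold higher number from compound 1 to compound 2 (0.42 log units; beyond the scatter), which swapped chloro for hydroxy on an aromatic carbon and lies beyond the scatter, though it is modest. Chloro and bromo are both halogens, so going from hydroxy to bromo looks like that step run backwards. This is an expectation resting on a single pair, and the swap of hydroxy for bromo itself has not been tested. A modest move toward a lower number in this assay, meaning stronger inhibition, therefore seems likely. The expected change is a 2.6-fold lower number from compound 2 to compound 3 (0.41 log units; beyond the scatter). For compound 3 the estimate is 60000 nM, with an expected range from 25000 nM to 130000 nM.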

Compound 3, half-maximal inhibitory concentration: 38200 nM
Compound 3: middle estimate off by 1.6-fold (0.20 log units), on the high side, and the stated range covers the measured number.
By their numbers in this assay, from the lowest: compounds 3 and 1 (each within the scatter of the next); then compound 2.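

In this assay, bromo in place of hydroxy on this aromatic carbon gives a 4.1-fold lower number from compound 2 to compound 3 (0.61 log units; beyond the scatter), so a second halogen now joins chloro on the stronger side of hydroxy, a contrast that earlier rested on a single pair. Between the two halogens, the change gives a 1.5-fold lower number from compound 1 to compound 3 (0.19 log units; within the scatter), which means that chloro and bromo cannot be told apart in this assay, while compound 2, with its hydroxy, stands apart from both. Nothing available shows whether the hydrogen-bond donor and acceptor that hydroxy carries and bromo lacks have any part in this difference.

The compounds shown leave open whether a halogen is what matters here or whether losing the hydroxy is enough, a question that a methyl group, a fluoro group or an amine at the same carbon would help to settle. Going by these compounds, it also remains open whether the same order holds for these groups on a different core or in a different kind of cell.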